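Predicting Compound 4 from Three Measured Analogues

The source may report more compounds than this note shows. Statements on the series, on what has been measured and on what is new or still open speak of the compounds shown alone.

All three measured compounds were tested in an assay on isolated protein for inhibition of protein kinase C zeta type (Homo sapiens), with stated times of 1 h and 2.5 min, tested at 30 uM; on this read-out lower numbers stand for less inhibition and higher numbers for more inhibition at the one concentration tested (going by the name of the read-out):

Compound 1, `CCOC(=O)c1c(-c2ccc(C)cc2)csc1N`, gives 80%.
Compound 2, `Cc1ccc(-c2csc(N)c2C(=O)OCc2ccccc2)cc1`, gives 60%.
Compound 3, `Nc1scc(-c2ccc(C(F)(F)F)cc2)c1C(=O)OCc1ccccc1`, gives 21%.

Compound 2 stands second highest of the three numbers: compound 1 sits above it, a number 20 percentage points lower from compound 1 to compound 2 (beyond the scatter), and compound 3 sits below it, a number 39 percentage points lower from compound 2 to compound 3 (beyond the scatter).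

Compound 4, `Nc1scc(-c2cccc(F)c2)c1C(=O)OCc1ccccc1`, has not yet been measured. It differs from compound 2 in one place: 3-fluorophenyl in place of 4-methylphenyl on an aromatic carbon.

Going by the values given here, of the two measured steps, the one from compound 2 to compound 3 also changed the group on that aromatic carbon and is the one that bears on compound 4; it was large, a number 39 percentage points lower from compound 2 to compound 3 (beyond the scatter). The step from compound 1 to compound 2 altered a different part of the molecule and says little here. A fall is therefore expected for compound 4 in this assay, though likely smaller than that seen with trifluoromethyl, giving an expected step of a number 20 percentage points lower from compound 2 to compound 4 (beyond the scatter). Compound 4 is estimated at 40%, within a range from 15% to 65%.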

Compound 4, a percentage reported as inhibition, at one concentration (the size of the read-out at that concentration, not a potency): 53%
The estimate for compound 4 lay 13 percentage points below the measured number, and the stated range covers the measured number.
By their numbers in this assay, from the lowest: compound 3; then compounds 4 and 2 (each within the scatter of the next); then compound 1.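

In this assay, putting 3-fluorophenyl in place of 4-methylphenyl gives a number 7 percentage points lower from compound 2 to compound 4 (within the scatter), so this position on the shared core accepts this different substituted phenyl group with no difference beyond the usual scatter. The earlier change at this position, a number 39 percentage points lower from compound 2 to compound 3 (beyond the scatter), therefore does not describe every replacement of 4-methylphenyl; it stands as one large step beside one small one. No measured information here explains why these two changes differ in size.

This single swap alters both the substituent and its place on the phenyl ring, so the compounds shown cannot separate the contribution of fluorine from that of its location. As far as these compounds go, it also remains open how this position would respond to a phenyl ring bearing an amine or a carboxylic acid, or to a phenyl ring with no substituent at all.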